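Five-membered aryl exchange on the shared core

The source may report more compounds than this note shows. Statements on the series, on what has been measured and on what is new or still open speak of the compounds shown alone.

Measured so far in a functional assay for inhibition, with Homo sapiens as the target; on this read-out lower numbers stand for stronger inhibition and higher numbers for weaker inhibition:
compound 1 `c1coc(-c2ccnc(Nc3ccc(-n4ccnc4)cc3)n2)c1`: 2200 nM
compound 2 `Cc1cccc(Nc2nccc(-c3cc(C)oc3C)n2)c1`: 28500 nM
compound 3 `COc1cccc(Nc2nccc(-c3ccsc3)n2)c1`: 1800 nM

Compound 3 gives the lowest of the three numbers in this assay. Compound 1 sits close beside it, within the usual scatter, so no order between the two can be read. Compound 2 lies far higher, well beyond the scatter. Among the measured compounds shown here, no two measured compounds differ in one place only, so no single step has been isolated.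

Compound 4 `COc1cccc(Nc2nccc(-c3ccc(C)o3)n2)c1` differs from compound 3 in one place: 5-methylfuran-2-yl in place of thiophen-3-yl on an aromatic carbon. The step from compound 3 to compound 4 is expected to be a moderate rise in the number, near the edge of the scatter, as a 2.2-fold higher number from compound 3 to compound 4 (0.35 log units; beyond the scatter). Compound 4 is estimated at 4000 nM, within 1500 nM to 12000 nM.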

Compound 4, half-maximal inhibitory concentration: 1500 nM
Compound 4: middle estimate off by 2.7-fold (0.43 log units), on the high side; the range from low to high includes it.
By their numbers in this assay, from the lowest: compounds 4, 3 and 1 (each within the scatter of the next); then compound 2.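

In this assay, among the compounds shown here, 5-methylfuran-2-yl in place of thiophen-3-yl gives a 1.2-fold lower number from compound 3 to compound 4 (0.08 log units; within the scatter), the first step isolated at one place. On this aromatic carbon, with the rest of compound 3 held fixed, the two five-membered aromatic rings cannot be told apart. No supporting data bear on this result.

Still open, going by these compounds, is how an amine or a carboxylic acid in place of the methyl of 5-methylfuran-2-yl would read at this position. Also open, on these data alone, is whether the same exchange reads alike with the other substituents on the shared core, such as those of compound 1 and compound 2.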